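This account rests on a few compounds, and the source may have more. Where it says the series, first, only, none or still open, it means among the compounds named here.

Working notes on the series. For the measured compounds named here, compound 1 `CCOC(=O)c1sc(-c2cccc(NC(=O)c3ccccc3)c2)nc1Nc1ccc(N2CCN(C)CC2)cc1` is the only member with a number in a functional assay on Ramos cells (Homo sapiens) for antiproliferative activity, read by CCK-8 assay, with a stated time of 72 h; a higher number here means a weaker inhibitor, a lower number a stronger inhibitor: in this assay compound 1 gives 24800 nM. Compound 2 `CCOC(=O)c1sc(-c2cccc(NC(=O)c3ccc(C(F)(F)F)cn3)c2)nc1Nc1ccc(N2CCN(C)CC2)cc1` was taken into this assay but no result was reported for it; the entry for compound 2 in this assay reads "not determined" (no result reported). Compound 3 `CN1CCN(c2ccc(Nc3nc(-c4cccc(NC(=O)c5ccccc5)c4)sc3C(=O)O)cc2)CC1` likewise has no result in this assay, the entry for compound 3 reading "not determined" (no result reported), so compound 3 stands without a single number, and the only fixed point for the whole set remains the value of compound 1. Compound 4 `CN1CCN(c2ccc(Nc3nc(-c4cccc(NC(=O)c5ccc(F)c(Cl)c5)c4)sc3C(=O)O)cc2)CC1` is the next member and is still to be measured in this assay.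

The change from compound 3 to compound 4 is 3-chloro-4-fluorophenyl in place of phenyl on a carbonyl carbon. Going by the values given here, no pair of measured compounds in the set differs in a single place, so no measured step is available to size this change in this assay, in either direction. On the evidence at hand the expectation for the step from compound 3 to compound 4 in this assay is none beyond the usual scatter, with the direction left open.

Among the compounds with values here, with compound 1 as the only anchor and compound 3 unmeasured, the inhibitory concentration of compound 4 in this assay is estimated at 20000 nM, expected to fall between 4000 nM and 100000 nM.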

Compound 4, half-maximal inhibitory concentration: 5600 nM
Compound 4: the middle estimate sits 3.6-fold (0.55 log units) above what was measured, and the stated range covers the measured number.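

No step can be read from the result for compound 4 in this assay: compound 3 has no single number there, and compound 1 differs from compound 4 in more than one place. As far as these compounds go, the effect of 3-chloro-4-fluorophenyl in place of phenyl on a carbonyl carbon stays open, in size and direction. No supporting evidence bears on this result.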